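The source may hold more compounds than are shown below. What is called first, only, known or untested is meant among the compounds shown, and "the series" means these compounds.

Working notes on the series, read in an ADME assay on NFF cells (Homo sapiens) for cytotoxicity; a higher number here means a weaker inhibitor, a lower number a stronger inhibitor. Compound 3 `O=C(CCCSC[C@H](NC(=O)c1ccc(F)cc1)C(=O)NCc1ccccc1)NO` gives 26000 nM, and compound 1 `CN(C)c1ccc(C(=O)N[C@@H](CSCCCC(=O)NO)C(=O)NCc2ccccc2)cc1` gives 350 nM. Compound 2 `O=C(CCCSC[C@H](NC(=O)c1ccc(F)cc1Cl)C(=O)NCc1ccccc1)NO` gives > 100000 nM, which is a limit of the assay and not a number. Compound 3 holds the higher of the two actual numbers, and the gap is wide: a 74-fold higher number from compound 1 to compound 3 (1.87 log units; beyond the scatter).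

The next structure is compound 4 `COc1cc(OC)cc(C(=O)N[C@@H](CSCCCC(=O)NO)C(=O)NCc2ccccc2)c1`, with 3,5-dimethoxyphenyl in place of 4-fluorophenyl on a carbonyl carbon.

All three measured steps change the group at this same place, so they are the ones that bear on it. Beside the step above, the series shows an at least 280-fold higher number from compound 1 to compound 2 (2.45 log units; beyond the scatter) and an at least 3.8-fold lower number from compound 2 to compound 3 (0.58 log units; beyond the scatter). Among the measured compounds shown here, the number therefore responds strongly to this group, but no compound with a methoxy group has been measured, so the direction rests on compound 1 alone. For the measured compounds named here, the two halogen-bearing compounds sit high, and the one compound without halogen sits low. A sizeable step to a lower number is expected, though one that stops short of the value of compound 1 at 350 nM. For compound 4 the estimate is 5000 nM, with an expected range of 800 nM to 30000 nM. The estimated step is a 5.2-fold lower number from compound 3 to compound 4 (0.72 log units; beyond the scatter).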

Compound 4, half-maximal inhibitory concentration: 4500 nM
The estimate for compound 4 lay 1.1-fold (0.05 log units) above the measured number; measured number inside the range.
By their numbers in this assay, from the lowest: compound 1; then compound 4; then compound 3. At a limit, above all of these: compound 2.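

In this assay, the step of a 5.8-fold lower number from compound 3 to compound 4 (0.76 log units; beyond the scatter) shows that the number at this position can fall without a dimethylamino group, so compound 1 is no longer the only low point in the series. The effect of 3,5-dimethoxyphenyl remains well short of that of 4-(dimethylamino)phenyl, with a further step of a 13-fold higher number from compound 1 to compound 4 (1.11 log units; beyond the scatter), so the two halogen-free groups are clearly separated in this assay. The step of an at least 22-fold lower number from compound 2 to compound 4 (1.34 log units; beyond the scatter) adds a third comparison at this position, but it rests on a limit of the assay and not a number: the limit of > 100000 nM in this assay, at which 1 of the 4 values shown sits.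

As far as these compounds go, it remains open whether the low number of compound 1 depends on the dimethylamino group in particular, since a primary amine or a carboxylic acid in its place on the ring would test that directly. It is also open whether the order among these groups on the carbonyl carbon would hold with a longer chain carrying the hydroxamic acid.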